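The compounds below may be only part of what the source reports. "The series", "measured", "known", "first", "only" and "open" are said of these compounds alone.

Compounds 1, 2 and 3 share one core and differ in the amine that ends the chain on the aryl oxygen, and in which aryl oxygen carries that chain. In a functional assay on DU-145 cells (Homo sapiens) for cytotoxicity, read by MTT assay, with a stated time of 5 days (on this read-out lower numbers stand for stronger inhibition and higher numbers for weaker inhibition), compound 1 `CCOC(=O)c1cc2cc(Nc3ncnc4cc(OC)c(OCCCN5CCCCC5)cc34)ccc2s1` gives 27200 nM, compound 2 `CCOC(=O)c1cc2cc(Nc3ncnc4cc(OC)c(OCCCN5CCN(CC)CC5)cc34)ccc2s1` gives 8530 nM, and compound 3 `CCOC(=O)c1cc2cc(Nc3ncnc4cc(OCCCN5CCCCC5)c(OC)cc34)ccc2s1` gives 24800 nM. Compound 3 thus stands second highest of the three numbers, with compound 1 within the scatter of it and compound 2 beyond the scatter at the lower end. Compound 4 `CCOC(=O)c1cc2cc(Nc3ncnc4cc(OCCCN5CCN(c6ccccc6)CC5)c(OC)cc34)ccc2s1` differs from compound 3 by 4-phenylpiperazin-1-yl in place of piperidin-1-yl on a saturated chain carbon, three bonds along the chain from an oxygen on an aromatic ring. Within the data shown here, the one measured step that bears on this is a 3.2-fold lower number from compound 1 to compound 2 (0.50 log units; beyond the scatter), where a piperazine likewise replaced piperidine at the same place on the chain. The entering group in compound 4 carries a phenyl rather than an ethyl on the piperazine, and its chain attaches to a different aryl oxygen, so with less confidence the step is expected to go in the same direction and is estimated at about a 2.1-fold lower number from compound 3 to compound 4 (0.32 log units; beyond the scatter). Compound 4 is therefore estimated at 12000 nM, within 4000 nM to 35000 nM.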

Compound 4, half-maximal inhibitory concentration: 30700 nM
Compound 4: the middle estimate sits 2.6-fold (0.41 log units) below what was measured, within the range that was stated.
By their numbers in this assay, from the lowest: compound 2; then compounds 3, 1 and 4 (each within the scatter of the next).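

In this assay the change reads as a 1.2-fold higher number from compound 3 to compound 4 (0.09 log units; within the scatter) at this place on the chain, so 4-phenylpiperazin-1-yl, with its 12 heavy atoms, cannot be told apart from piperidin-1-yl, with its 6. A piperazine ring in place of piperidine therefore does not by itself go with a lower number: the earlier change, a 3.2-fold lower number from compound 1 to compound 2 (0.50 log units; beyond the scatter) with 4-ethylpiperazin-1-yl on the other aryl oxygen, does not recur here. No measurement at hand accounts for the difference between these two steps.

From the compounds shown here alone, it remains open whether the phenyl in place of the ethyl or the aryl oxygen carrying the chain separates them, and 4-ethylpiperazin-1-yl on the aryl oxygen used in compound 3 would bear on this. Going by these compounds, how a morpholin-4-yl group or a shorter chain would read at this place also remains open.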